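The source may hold more compounds than are shown below. What is called first, only, known or untested is meant among the compounds shown, and "the series" means these compounds.

Values in a functional assay on DLD-1 cells (Homo sapiens) for antiproliferative activity, read by trypan blue exclusion; a lower number here means a stronger inhibitor, a higher number a weaker inhibitor:
compound 1, `COc1ccc(CS(=O)(=O)/C=C/c2ccc(OC)cc2OC)cc1`: > 20000 nM
compound 2, `COc1ccc(CS(=O)(=O)/C=C/c2cc(OC)ccc2OC)cc1`: > 20000 nM

Both figures are limits of this assay rather than numbers. For compound 1 the figure > 20000 nM is a limit. For compound 2 the figure > 20000 nM is likewise a limit. Going by the values given here, compound 2 therefore stands at the limit, together with compound 1, as recorded in the limit of > 20000 nM in this assay, at which 2 of the 2 values shown sit; no order between the two compounds can be read from these figures, and no measured step between them exists.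

Compound 3, `COc1ccc(CS(=O)(=O)/C=C/c2cc(OC)c(OC)cc2OC)cc1`, differs from compound 2 in one place: methoxy in place of hydrogen on an aromatic carbon. Among the compounds with values here, with no measured step in the set, nothing here tells how large a change this kind of addition brings in this assay. The working expectation is that compound 3 stays close to where compound 2 sits, with a chance of a modest shift toward a measurable number; a change beyond the scatter in either direction cannot be excluded. For compound 3 the expected value in this assay is 15000 nM, within a range from 4000 nM to 40000 nM. The step that this estimate implies is an at least 1.3-fold lower number from compound 2 to compound 3 (0.12 log units; that floor lies within the scatter).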

Compound 3, half-maximal inhibitory concentration: > 20000 nM
Compound 3: only a limit was reported; the forecaster's own chance of this, stated with the estimate: 65%; middle value at least 1.3-fold (0.12 log units) away from the limit.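

In this assay compound 3 gives > 20000 nM as a limit of the assay and not a number. No step from compound 1 or compound 2 to compound 3 can be read, since all three values are limits: the limit of > 20000 nM in this assay, at which 3 of the 3 values shown sit.

The compounds shown leave open how far the added methoxy moves the value, and in which direction.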